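The source may report more compounds than this note shows. Statements on the series, on what has been measured and on what is new or still open speak of the compounds shown alone.

Compound 1 `COc1cc(-c2ncnn2-c2cccc(N)c2)cc(OC)c1OC`: > 10000 nM (a limit)
Compound 2 `COc1cc(-n2ncnc2-c2ccc(OC(F)(F)F)cc2)cc(OC)c1OC`: > 10000 nM (a limit)
Compound 3 `COc1cc(-c2ncnn2-c2ccc(Cl)c(Cl)c2)cc(OC)c1OC`: not yet measured

In a functional assay on MCF7 cells (Homo sapiens) for antiproliferative activity, read by MTT assay, with a stated time of 72 h (on this read-out higher numbers stand for weaker inhibition and lower numbers for stronger inhibition), compound 1 gives > 10000 nM, a limit of the assay and not a number. Compound 2 gives > 10000 nM, also a limit. Neither compound has a numerical value, and the record shows (the limit of > 10000 nM in this assay, at which 2 of the 2 values shown sit). Compound 3 carries 3,4-dichlorophenyl in place of 3-aminophenyl on an aromatic nitrogen of the shared core: 3,4-dichlorophenyl in place of 3-aminophenyl on an aromatic nitrogen. No measured step sizes this change, so no step beyond the scatter is expected in this assay. For compound 3 the estimated value is 10000 nM, with an expected range from 2500 nM to 30000 nM.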

Compound 3, half-maximal inhibitory concentration: > 10000 nM
Compound 3: only a limit was reported (the forecaster's own chance of this, stated with the estimate: 65%); the middle value sits exactly at the limit.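

Compound 1 and compound 3 both stop at a limit, so the step between them cannot be read: the limit of > 10000 nM in this assay, at which 3 of the 3 values shown sit. The compounds shown leave open whether any group at this place on the shared core gives a numerical value.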